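The compounds below may be only part of what the source reports. "The series", "measured", "known", "first", "only" and "open" are said of these compounds alone.

Of the compounds shown here, two with one shared core have been read so far in an ADME assay on microsomes from liver (Homo sapiens) for metabolic stability, read by LC-MS, with NADPH named in the record, with a stated time of 60 min, tested at 1 uM, in the absence of a further agent (on this read-out higher numbers stand for a more stable compound and lower numbers for a less stable compound), and both end at the same limit. Compound 1 `COc1ccc(-c2c(C)nc3c(N4CC[C@@H](NS(=O)(=O)C5CC5)C4)cc(C)nn23)cc1OC` carries cyclopropyl on a sulfonyl sulfur and gives > 95% as a limit of the assay, not a number. Compound 2 `COc1ccc(-c2c(C)nc3c(N4CC[C@@H](NS(N)(=O)=O)C4)cc(C)nn23)cc1OC` has amino in that place and gives > 95% as a limit too. Compound 2 therefore stands at the limit of > 95% in this assay, at which 2 of the 2 values shown sit, and has no exact figure. Among the measured compounds shown here, the only measured step is a step that the two limits leave unreadable from compound 1 to compound 2 and so offers no size to carry forward. Compound 3 `COc1ccc(-c2c(C)nc3c(N4CC[C@H](O)C4)cc(C)nn23)cc1OC` differs from compound 2 by the change 3-hydroxypyrrolidin-1-yl in place of 3-(sulfamoylamino)pyrrolidin-1-yl on an aromatic carbon in which 3-hydroxypyrrolidin-1-yl replaces 3-(sulfamoylamino)pyrrolidin-1-yl on an aromatic carbon, while the shared core stays. Neither measured compound has fallen short of the limit in this assay so the data show no loss, and a step beyond the usual scatter is not expected. The expected move is a number at least 3 percentage points lower from compound 2 to compound 3 (that floor lies within the scatter) in this estimate, though a modest fall remains possible. For compound 3 the estimated percent remaining is 92% with an expected range from 78% to 99% at the end of the incubation.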

Compound 3, percent of the compound remaining: > 95%
Compound 3 ended at the assay's limit (the forecaster's own chance of this, stated with the estimate: 45%); at least 3 percentage points between middle value and limit.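

No size can be read for the change from compound 2 to compound 3 in this assay, because their values are limits of the assay and not numbers: the limit of > 95% in this assay, at which 3 of the 3 values shown sit.

The compounds shown leave open how far compound 1, compound 2 and compound 3 differ in stability, and which change on the shared core would give an exact figure.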